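Replacing the piperidinylmethyl arm of compound 1 with a small amide

A few compounds are considered here, and "the series" means these few. Any claim that something is new, unique, unknown or untested is made for them only; others in the source may bear on it.

Compound 1 `COC(=O)CC1CCN(C[C@H]2CN(c3ccc(-n4cc(-c5ccccn5)cn4)c(F)c3)C(=O)O2)CC1` stands at a limit of the assay: in an ADME assay on L02 cells (Homo sapiens) for cytotoxicity, read by MTT assay, with a stated time of 48 h (on this read-out higher numbers stand for weaker inhibition and lower numbers for stronger inhibition), compound 1 gives > 400 ug/mL, so only a bound and no number is known for it (the limit of > 400 ug/mL in this assay, at which 2 of the 3 values shown sit). Compound 2 `O=C1O[C@@H](Cn2ccnn2)CN1c1ccc(-n2cc(-c3ccccn3)cn2)c(F)c1` gives 49 ug/mL in this assay, a step of an at least 8.1-fold lower number from compound 1 to compound 2 (0.91 log units; beyond the scatter). Compound 3 `O=CNC[C@H]1CN(c2ccc(-n3cc(-c4ccccn4)cn3)c(F)c2)C(=O)O1` also sits at a limit, giving > 400 ug/mL in this assay; the step that the two limits leave unreadable from compound 1 to compound 3 is therefore not readable, while an at least 8.1-fold higher number from compound 2 to compound 3 (0.91 log units; beyond the scatter) is.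

Compound 4 `CNC(=O)[C@H]1CN(c2ccc(-n3cc(-c4ccccn4)cn3)c(F)c2)C(=O)O1` has not been measured. It differs from compound 1 by methylcarbamoyl in place of (4-((methoxycarbonyl)methyl)piperidin-1-yl)methyl on a saturated ring carbon. Going by the values given here, of the measured steps, the exchange for a small neutral group is closest to compound 3, where the limit was kept, whereas the triazolyl change gave the only numeric value. No step beyond the scatter is expected in the direction of a lower number. Compound 4 is therefore estimated at 350 ug/mL in this assay, with a range from 100 ug/mL to 400 ug/mL, the expected step being an at least 1.1-fold lower number from compound 1 to compound 4 (0.05 log units; that floor lies within the scatter).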

Compound 4, half-maximal inhibitory concentration: 217 ug/mL
Compound 4: the middle estimate sits 1.6-fold (0.21 log units) above what was measured; measured number inside the range.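

With methylcarbamoyl on the saturated ring carbon, compound 4 gives the series a number that does not depend on the triazolyl arm, and the step from the triazole remains beyond the scatter (a 4.4-fold higher number from compound 2 to compound 4 (0.65 log units; beyond the scatter)). So the low number of compound 2 in this assay is not shared by every small group here, although compound 4 does show that a compound without the triazolyl arm can fall short of the limit. Compounds 1 and 3 each stand at a limit, so the steps to compound 4 are floors only (an at least 1.8-fold lower number from compound 1 to compound 4 (0.26 log units; that floor lies within the scatter) and an at least 1.8-fold lower number from compound 3 to compound 4 (0.26 log units; that floor lies within the scatter)), and neither floor exceeds the scatter.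

As far as these compounds go, how far compound 4 truly lies from compounds 1 and 3 stays open. Also open, from the compounds shown here alone, is whether an amine or a carboxylic acid on this ring carbon would read nearer compound 2 or compound 4.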